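Compound 3 and the swap to 3-nitrophenyl

The source may report more compounds than this note shows. Statements on the series, on what has been measured and on what is new or still open speak of the compounds shown alone.

Of the compounds shown here, three have numbers so far in an ADME assay on L02 cells (Homo sapiens) for cytotoxicity, read by MTT assay, with a stated time of 24 h; on this read-out higher numbers stand for weaker inhibition and lower numbers for stronger inhibition. Compound 1 `CN1C/C(=C\c2ccc(C(C)(C)C)cc2)C(=O)/C(=C/c2ccccc2F)C1` gives 25800 nM, compound 2 `COc1cc(/C=C2\CN(C)C/C(=C\c3ccc(F)cc3)C2=O)cc(OC)c1` gives 21900 nM, and compound 3 `COc1cc(/C=C2\CN(C)C/C(=C\c3ccc(F)cc3)C2=O)cc(OC)c1OC` gives 10700 nM. Compound 3 holds the lowest of the three numbers, beyond the scatter from both of the others.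

The next compound, compound 4 `COc1cc(/C=C2\CN(C)C/C(=C\c3cccc([N+](=O)[O-])c3)C2=O)cc(OC)c1OC`, carries 3-nitrophenyl in place of 4-fluorophenyl on a double-bonded chain carbon bound to a double-bonded ring carbon. The rest of compound 3 stays as it is.

Among the measured compounds shown here, only one measured step is available, a 2.0-fold lower number from compound 2 to compound 3 (0.31 log units; beyond the scatter), a modest change with methoxy in place of hydrogen on an aromatic carbon. It leaves 4-fluorophenyl untouched, so it bears only weakly on this swap. For the measured compounds named here, no measured pair replaces 4-fluorophenyl, and no measured compound carries 3-nitrophenyl. The best remaining guide is the narrow span from compound 3 at 10700 nM to compound 1 at 25800 nM. On that basis, no step beyond the scatter is expected in this assay, and no direction can be assigned. The expected step is a 1.0-fold higher number from compound 3 to compound 4 (0.01 log units; within the scatter). For compound 4 the estimated value is 11000 nM, with an expected range of 4500 nM to 26000 nM.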

Compound 4, half-maximal inhibitory concentration: 13600 nM
Estimate against measurement, compound 4: 1.2-fold (0.09 log units) below; low and high end bracket the measured number.
By their numbers in this assay, from the lowest: compounds 3, 4, 2 and 1 (each within the scatter of the next, the first and the last beyond it).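

In this assay, among the compounds shown here, the first measured change on a double-bonded chain carbon bound to a double-bonded ring carbon is a 1.3-fold higher number from compound 3 to compound 4 (0.10 log units; within the scatter) and stays within the scatter, even though the entering 3-nitrophenyl carries hydrogen-bond acceptors and the leaving 4-fluorophenyl carries none. For the compounds shown here, the one earlier step, a 2.0-fold lower number from compound 2 to compound 3 (0.31 log units; beyond the scatter) on the other aromatic ring, is printed as beyond the scatter, so in these two pairs only the methoxy change moves the number by more than the scatter, while this first swap at the new position does not. No measurement on hand explains why the number holds through this swap.

A single swap on a single background cannot show whether this position tolerates change in general, and a phenyl bearing an amine or a carboxylic acid, or a longer chain in place of the aryl group, could still give a step beyond the scatter. From the compounds shown here alone, it also remains open whether 3-nitrophenyl would give the same result on the background of compound 2, which lacks the added methoxy.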